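This account rests on a few compounds, and the source may have more. Where it says the series, first, only, none or still open, it means among the compounds named here.

Three compounds sharing one core have been examined in an ADME assay on microsomes from liver (Homo sapiens) for metabolic stability; on this read-out higher numbers stand for fast clearance and lower numbers for slow clearance. Compound 1, `CC(NC(=O)Cn1nnc2ccccc2c1=O)c1ccc(Cl)cc1`, returns a value that is a limit of the assay rather than a number, < 9.9 mL/min/kg. Compound 2, `Cc1cccc([C@H](C)NC(=O)Cn2nnc3ccccc3c2=O)c1`, gives 11 mL/min/kg in this assay. Compound 3, `Cc1ccc([C@H](C)NC(=O)C(C)n2nnc3ccccc3c2=O)cc1`, gives 13 mL/min/kg in this assay. Of the two numbers reported, compound 2 carries the lower, yet its gap to compound 3 lies within the scatter, so the two cannot be told apart.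

Compound 4, `C[C@H](NC(=O)Cn1nnc2ccccc2c1=O)c1nccs1`, has not yet been measured in this assay. It differs from compound 2 in one place: 1,3-thiazol-2-yl in place of 3-methylphenyl on a saturated chain carbon bound to an amide-type nitrogen and a saturated chain carbon. For the measured compounds named here, no step between measured compounds covers this change, so there is no direct precedent. The expectation is that the step in this assay, a 1.2-fold lower number from compound 2 to compound 4 (0.09 log units; within the scatter), remains modest, leaning if anywhere toward slower clearance. Compound 4 is therefore estimated at 9 mL/min/kg, with a range from 5 mL/min/kg to 16 mL/min/kg.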

Compound 4, clearance: < 9.9 mL/min/kg
Compound 4 gave a limit, no number; the forecaster's own chance of this, stated with the estimate: 40%; the middle value does not contradict the limit.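

The change from 3-methylphenyl to 1,3-thiazol-2-yl on this saturated chain carbon gives the first step among these compounds that can be read in this assay, and it is an at least 1.1-fold lower number from compound 2 to compound 4 (0.04 log units; that floor lies within the scatter). At this place, a five-membered aromatic ring with 2 hetero atoms can therefore stand in for the six-membered carbon ring with no rise in the read-out, though the floor of the step does not go beyond the scatter. The full size of the step cannot be told, because the result for compound 4 is a limit of the assay and not a number: the limit of < 9.9 mL/min/kg in this assay, at which 2 of the 4 values shown sit.

From the compounds shown here alone, whether a pyridin-2-yl or a cyclohexyl group in the same place would also reach this limit remains open. Also open, going by these compounds, is whether 1,3-thiazol-2-yl would behave the same way on the chain of compound 3.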